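Ester for Nitrile on the Chain of Compound 2

This account rests on a few compounds, and the source may have more. Where it says the series, first, only, none or still open, it means among the compounds named here.

Measured in an assay on isolated protein for binding affinity to leukotriene B4 receptor 1 (Homo sapiens), tested at 1 uM; a lower number here means less inhibition, a higher number more inhibition at the concentration tested (going by the name of the read-out):
compound 1, `CCCCCc1cc(C(C)=O)c(O)cc1OCCCCC#N` — 14%
compound 2, `C=CCc1cc(C(C)=O)c(O)cc1OCCCCCCCCC#N` — 50%
compound 3, `CCc1cc(C(C)=O)c(O)cc1OCCCCCCS(C)(=O)=O` — 62%

Compound 2 stands second highest among the three numbers. Its nearest neighbour is compound 3, whose inhibition is higher by a margin beyond the usual scatter; furthest from it is compound 1, whose inhibition is lower by a much wider margin, also beyond the scatter. No two of the three compounds differ in only one place, so none of these gaps can be tied to a single structural change.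

Compound 4, `C=CCc1cc(C(C)=O)c(O)cc1OCCCCCC(=O)OC`, is not yet measured. Relative to compound 2 it carries methoxycarbonyl in place of 3-cyanopropyl on a saturated chain carbon, five bonds along the chain from an oxygen on an aromatic ring. Going by the values given here, no step of this kind has been measured in this set, so there is no direct guide for the size of the change. One polar end group on a saturated chain is exchanged for another, with the chain read one atom shorter. Compound 4 is expected to fall somewhat below compound 2, with the step of a number 10 percentage points lower from compound 2 to compound 4 (within the scatter) expected to be modest and possibly within the scatter. Compound 4 is accordingly estimated at 40%, with a plausible range from 15% to 65%.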

Compound 4, a percentage reported as inhibition, at one concentration (the size of the read-out at that concentration, not a potency): 65%
For compound 4 the middle estimate is 25 percentage points below the measured one; measured number inside the range.
By their numbers in this assay, from the lowest: compound 1; then compound 2; then compounds 3 and 4 (each within the scatter of the next).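

In this assay, putting methoxycarbonyl in place of 3-cyanopropyl gives a number 15 percentage points higher from compound 2 to compound 4 (beyond the scatter), the first difference in this set that can be tied to a single structural change. It shows that inhibition at the concentration tested responds to what is carried on the saturated chain carbon, five bonds along the chain from an oxygen on an aromatic ring, and that here the chain with the ester end gives the higher number, even though methoxycarbonyl has 4 heavy atoms against 5 in 3-cyanopropyl. The step changes the end group and the chain length together, so it cannot be assigned to either one alone, and nothing available explains the gain.

From the compounds shown here alone, it remains open whether a nitrile and a methoxycarbonyl end would differ in the same way on chains of matched length, and whether a carboxylic acid or a primary amide at the chain end, or methoxycarbonyl on a longer chain, would hold this level. Going by these compounds, it is also open whether the step carries over to compounds with a propyl or pentyl group in place of the allyl group on the shared core.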